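Swapping the benzyl ether substituent in a GPR39 agonist series

This account rests on a few compounds, and the source may have more. Where it says the series, first, only, none or still open, it means among the compounds named here.

Measured compounds:
- compound 1, `Cc1nn(-c2ncnc3nc[nH]c23)c2c1C(OCC(=O)c1ccc(F)cc1)CC(=O)N2`: 3 nM
- compound 2, `Cc1nn(-c2ncnc3nc[nH]c23)c2c1C(OCc1ccccc1C#N)CC(=O)N2`: 8 nM
- compound 3, `CC(C)(C)c1cc(C(=O)N/N=C/c2ccc(O)cc2O)[nH]n1`: 240 nM

In a functional assay on HEK293 cells for agonist activity at G-protein coupled receptor 39 (Homo sapiens), read by scintillation proximity assay and inositol phosphate accumulation, with a stated time of 75 min, in the presence of a further agent that is not named here (on this read-out lower numbers stand for an effect already at smaller amounts and higher numbers for an effect only at larger amounts of compound), compound 2 gives 8 nM. Among the three measured compounds this is the second highest number: compound 1 lies closest, with a lower number, while compound 3 gives 240 nM, far higher. Compound 3 shares no core with compound 2, so it shows only how wide the numbers in this series can range.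

The unmeasured compound 4, `Cc1nn(-c2ncnc3nc[nH]c23)c2c1C(OCc1ccc(F)cc1)CC(=O)N2`, keeps the core of compound 2 and changes one group:

4-fluorophenyl in place of 2-cyanophenyl on a saturated chain carbon bound to an oxygen on a saturated carbon

Cut one bond further out, the (2-cyanobenzyl)oxy group becomes a (4-fluorobenzyl)oxy group. Within the data shown here, only one measured step touches this position: a 2.7-fold higher number from compound 1 to compound 2 (0.43 log units; beyond the scatter). That step compares a (4-fluorophenyl)carbonyl with a 2-cyanophenyl on the same chain carbon, so compound 4 combines the 4-fluorophenyl of compound 1 with the plain benzyl arrangement of compound 2. Among the measured compounds shown here, no measured pair separates these two parts, so in this assay the step is expected to be small, and compound 4 is expected to sit near compound 2, with a 1.1-fold higher number from compound 2 to compound 4 (0.05 log units; within the scatter) as the likely outcome. Compound 4 is therefore estimated at 9 nM, within a range from 3 nM to 30 nM.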

Compound 4, half-maximal effective concentration: 1 nM
The estimate for compound 4 lay 9.0-fold (0.95 log units) above the measured number, and the stated range ends above it.
By their numbers in this assay, from the lowest: compound 4; then compound 1; then compound 2; then compound 3.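

In this assay, among these compounds, the step of an 8.0-fold lower number from compound 2 to compound 4 (0.90 log units; beyond the scatter) shows that this position, on a saturated chain carbon bound to an oxygen on a saturated carbon, responds clearly when 4-fluorophenyl replaces 2-cyanophenyl, which the earlier compounds could not show on their own. The step of a 3.0-fold lower number from compound 1 to compound 4 (0.48 log units; beyond the scatter) adds a second finding: with the 4-fluorophenyl kept, taking away the carbonyl of the (4-fluorophenyl)carbonyl group does not raise the number but lowers it beyond the usual scatter, so among these compounds the carbonyl is not needed for a low number. No measurement offered here gives a reason for either step.

On these data alone, what remains open is whether the step from the 2-cyanophenyl compound comes from losing the nitrile or from gaining the fluorine, and a plain phenyl group carrying neither would be the natural comparison. As far as these compounds go, it is also open how far this position accepts a very different group, such as an amine, a carboxylic acid or a longer chain in place of the 4-fluorophenyl.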